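Benzoyl to hydrogen in compound 1: working notes

The source may report more compounds than this note shows. Statements on the series, on what has been measured and on what is new or still open speak of the compounds shown alone.

Measured so far in a functional assay on U-118-MG cells (Homo sapiens) for cytotoxicity, read by MTT assay, with a stated time of 48 h; on this read-out lower numbers stand for stronger inhibition and higher numbers for weaker inhibition:
compound 1 `O=C(O[C@H]1C[C@H](n2cc(F)c(=O)[nH]c2=O)O[C@@H]1COP(=O)(O)Oc1ccc2ncccc2c1)c1ccccc1` gives 790 nM here
compound 2 `CCOC(=O)C[n+]1cccc(OP(=O)([O-])OC[C@H]2O[C@@H](n3cc(F)c(=O)[nH]c3=O)C[C@@H]2OC(=O)c2ccccc2)c1` gives 1540 nM here

Compound 1 at 790 nM and compound 2 at 1540 nM lie within the usual scatter of each other, so the two values cannot be separated and compound 1 has no clear place of its own in the series.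

The next compound to read is compound 3 `O=c1[nH]c(=O)n([C@H]2C[C@H](O)[C@@H](COP(=O)(O)Oc3ccc4ncccc4c3)O2)cc1F`, which is compound 1 with the ester removed: hydrogen in place of benzoyl on an oxygen on a saturated carbon (hydrogen in place of benzoyl on an oxygen on a saturated carbon, or benzoyloxy to hydroxy). Among the compounds with values here, no measured pair covers this change, so any expectation rests on judgement and carries a wide margin. The group lost is sizeable, so a move beyond the scatter seems more likely than none. The expected change is a 3.2-fold higher number from compound 1 to compound 3 (0.50 log units; beyond the scatter) in this assay and points towards a higher number, meaning weaker inhibition. In this assay the estimated value for compound 3 is 2500 nM with an expected range from 600 nM to 10000 nM as the working figure.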

Compound 3, half-maximal inhibitory concentration: 7070 nM
For compound 3 the middle estimate is 2.8-fold (0.45 log units) below the measured one; measured number inside the range.
By their numbers in this assay, from the lowest: compounds 1 and 2 (each within the scatter of the next); then compound 3.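

In this assay, within the data shown here, hydrogen in place of benzoyl on an oxygen on a saturated carbon gives an 8.9-fold higher number from compound 1 to compound 3 (0.95 log units; beyond the scatter), the only step so far that can be read and one that lies beyond the scatter. This position therefore matters for the read-out: within this pair, benzoyloxy goes with the lower number and hydroxy with the higher number, meaning weaker inhibition. The pair shows only the net effect of removing the whole benzoyl group, and no measurement bearing on the reason for the step is available.

The compounds shown leave open whether an acetyl group on this oxygen, which would keep the ester but carry no six-membered aromatic ring, would stay close to compound 1 or move towards compound 3. They also leave open whether benzoyl to hydrogen would give a step of similar size and direction when made on compound 2, so the present reading rests on a single pair and should not yet be extended to the rest of the series.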